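The source may report more compounds than this note shows. Statements on the series, on what has been measured and on what is new or still open speak of the compounds shown alone.

Working notes on a homologous sulfonamide-linked isothiocyanate series, all sharing the same core.

Compound 1 `CN(C)C(=O)c1cc2cnc(Nc3ccc(S(=O)(=O)NCCCN=C=S)cc3)nc2n1C1CCCC1` gives 102% in a functional assay on A549 cells (Homo sapiens) for inhibition, read by CCK-8 assay, with a stated time of 72 h, tested at 10 uM; on this read-out lower numbers stand for a weaker effect and higher numbers for a stronger effect at the one concentration tested. Compound 2 `CN(C)C(=O)c1cc2cnc(Nc3ccc(S(=O)(=O)NCCCCN=C=S)cc3)nc2n1C1CCCC1` gives 101% in this assay, and compound 3 `CN(C)C(=O)c1cc2cnc(Nc3ccc(S(=O)(=O)NCCCCCCN=C=S)cc3)nc2n1C1CCCC1` gives 101% in this assay. Between compound 1 and compound 2 the change is a group of 4 heavy atoms (2 carbon, 1 nitrogen, 1 sulfur; no ring) in place of a group of 3 heavy atoms (1 carbon, 1 nitrogen, 1 sulfur; no ring), on a saturated chain carbon, three bonds along the chain from a sulfonamide nitrogen; the corresponding step in this assay is a number 1 percentage points lower from compound 1 to compound 2 (within the scatter). The two cores of compound 1 and compound 3 differ by a group of 6 heavy atoms (4 carbon, 1 nitrogen, 1 sulfur; no ring) in place of a group of 3 heavy atoms (1 carbon, 1 nitrogen, 1 sulfur; no ring), on a saturated chain carbon, three bonds along the chain from a sulfonamide nitrogen. All three measured members sit at essentially complete inhibition at the single concentration used, with no separation beyond the scatter.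

Compound 4 `CN(C)C(=O)c1cc2cnc(Nc3ccc(S(=O)(=O)NCCCCCCCN=C=S)cc3)nc2n1C1CCCC1` has not been measured in this assay. It differs from compound 3 by a group of 4 heavy atoms (2 carbon, 1 nitrogen, 1 sulfur; no ring) in place of a group of 3 heavy atoms (1 carbon, 1 nitrogen, 1 sulfur; no ring), on a saturated chain carbon, six bonds along the chain from a sulfonamide nitrogen. This is the same kind of change as from compound 1 to compound 2, but the place is not the same: there the change sat three bonds along the chain from a sulfonamide nitrogen, here six bonds along the chain from a sulfonamide nitrogen. Because the earlier step of a number 1 percentage points lower from compound 1 to compound 2 (within the scatter) stayed within the scatter, the step of a number 1 percentage points lower from compound 3 to compound 4 (within the scatter) is expected to be small as well, given that the read-out is already near its ceiling. Compound 4 is therefore estimated at 100% in this assay.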

Compound 4, a percentage reported as inhibition, at one concentration (the size of the read-out at that concentration, not a potency): 101%
Compound 4: middle estimate off by 1 percentage points, on the low side; the measured number falls inside the stated range.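

In this assay the longer group, on a saturated chain carbon six bonds along the chain from a sulfonamide nitrogen, gives no change at the digits printed from compound 3 to compound 4 (within the scatter), and this agrees with the same change made three bonds along the chain: the same change on two cores in this assay, a number 1 percentage points lower (within the scatter) from compound 1 to compound 2 and no change at the digits printed (within the scatter) from compound 3 to compound 4, 1 percentage points apart, within the scatter of two such steps. The wider chain changes read alike, with no change at the digits printed from compound 2 to compound 4 (within the scatter) and a number 1 percentage points lower from compound 1 to compound 4 (within the scatter), and the second pairing also agrees: the same change on two cores in this assay, a number 1 percentage points lower (within the scatter) from compound 1 to compound 3 and no change at the digits printed (within the scatter) from compound 2 to compound 4, 1 percentage points apart, within the scatter of two such steps. Across these four compounds, the chain change therefore carries from one core to another without a visible difference, but all the numbers sit at essentially complete inhibition at one concentration, so this does not show that the compounds would give an equally strong effect at other concentrations or that the change would stay silent on a read-out with room to move.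

Any separation among these chains at lower concentrations remains open, as does the contribution of the isothiocyanate end to the inhibition seen. Also open, going by these compounds, is how an amine or a carboxylic acid at the chain end, or a longer chain, would read in this assay.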